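A few compounds are considered here, and "the series" means these few. Any claim that something is new, unique, unknown or untested is made for them only; others in the source may bear on it.

Values so far in a functional assay on HT-22 cells (Mus musculus), read by MTT assay, with a stated time of 24 h; a lower number here means that less compound is needed, a higher number that more compound is needed for the effect:
compound 1 (`CCC(CC)c1cc(/C=C/c2cc(O)cc(O)c2)cc(C(CC)CC)c1O`) gives 30 nM
compound 2 (`CCC(CC)c1cc(/C=C/C=C/c2cc(O)cc(O)c2)ccc1O`) gives 79 nM
compound 3 (`CC(C)(C)c1cc(/C=C/C=C/c2cc(O)cc(O)c2)ccc1O`) gives 91 nM

Within the data shown here, compound 3 stands level with compound 2, as the one measured single change between them is a 1.2-fold higher number from compound 2 to compound 3 (0.06 log units; within the scatter) and this swaps pentan-3-yl for tert-butyl. Compound 1 (30 nM) lies lower than both.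

Compound 4 (`CC(C)(C)c1cc(/C=C/C=C/c2cc(O)cc(O)c2)cc(C(C)(C)C)c1O`) differs from compound 3 by one change (tert-butyl in place of hydrogen on an aromatic carbon), tert-butyl in place of hydrogen on an aromatic carbon, ortho to a hydroxy group. Among the measured compounds shown here, no measured step isolates such an addition, so the evidence is indirect. The step to compound 3 suggests that tert-butyl and pentan-3-yl can be treated as near equivalents in this assay here. Compound 1 carries two pentan-3-yl groups, whereas compound 2 (79 nM) carries one. However, the two also differ elsewhere, so their values cannot be credited to the second group alone. On that limited basis, a moderate move towards a lower number is expected. The estimated step is a 2.3-fold lower number from compound 3 to compound 4 (0.36 log units; beyond the scatter) and a result within the scatter would not be surprising. Compound 4 is expected at 40 nM, with an estimated range from 14 nM to 110 nM.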

Compound 4, half-maximal effective concentration: 119 nM
The estimate for compound 4 lay 3.0-fold (0.47 log units) below the measured number, outside the stated range (above it).
By their numbers in this assay, from the lowest: compound 1; then compounds 2, 3 and 4 (each within the scatter of the next).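

In this assay, adding a tert-butyl group ortho to a hydroxy group and meta to the existing tert-butyl group gives a 1.3-fold higher number from compound 3 to compound 4 (0.12 log units; within the scatter) and so leaves the number within the scatter. Among these compounds, this is the first measured step that fills this position on an aromatic carbon instead of exchanging one group for another elsewhere, and hydrogen and tert-butyl cannot be told apart here in this read-out. The result therefore gives no sign that a second bulky alkyl group at this position, taken alone, moves the half-maximal effective concentration on this core. Nothing shown bears on the reason for this outcome.

The compounds shown leave open whether a small group such as methyl, or a group carrying atoms other than carbon such as methoxy or an amine, would also stay within the scatter of compound 3 at this position. They also leave open whether a second pentan-3-yl group added to compound 2 would behave as the second tert-butyl group does here.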